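A few compounds are considered here, and "the series" means these few. Any claim that something is new, unique, unknown or untested is made for them only; others in the source may bear on it.

Measured so far in an ADME assay on PANC-1 cells (Homo sapiens) for cytotoxicity, read by sulforhodamine B assay, with a stated time of 48 h, tested at 10 uM; on this read-out higher numbers stand for more inhibition at the one concentration tested (going by the name of the read-out) and lower numbers for less inhibition:
compound 1, `COc1nc2ccc(Br)cc2cc1C(c1ccccc1)n1cc(-c2ccc(Br)cc2)nn1`, gives 10.4%
compound 2, `COc1nc2ccc(Br)cc2cc1C(c1ccccc1)n1cc(-c2ccccc2F)nn1`, gives 14.7%
compound 3, `CCCCCc1cn(C(c2ccccc2)c2cc3cc(Br)ccc3nc2OC)nn1`, gives 5.07%

Compound 3 stands lowest of the three numbers, but its gaps to the other two are small: a number 5.3 percentage points lower from compound 1 to compound 3 (within the scatter) and a number 9.6 percentage points lower from compound 2 to compound 3 (within the scatter), both within the scatter. The two aryl-bearing compounds also sit within scatter of each other, a number 4.3 percentage points higher from compound 1 to compound 2 (within the scatter). All three values therefore describe one flat level of inhibition in this assay at the single concentration tested.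

Compound 4, `COc1nc2ccc(Br)cc2cc1C(c1ccccc1)n1cc(-c2ccc(OC(F)(F)F)cc2)nn1`, is the next member. Relative to compound 3 the change is 4-(trifluoromethoxy)phenyl in place of pentyl on an aromatic carbon. Within the data shown here, the steps that bear on it are the two that exchange an aryl group for pentyl at the same position, from compound 1 and from compound 2 to compound 3; compound 4 runs that exchange in the reverse direction, with a different aryl group. As both of those steps stayed within the scatter, the expected step of a number 5.9 percentage points higher from compound 3 to compound 4 (within the scatter) is likewise no more than the scatter, if anything toward the level of compound 1 and compound 2. Compound 4 is estimated at 11%, with a range from 3% to 20%.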

Compound 4, a percentage reported as inhibition, at one concentration (the size of the read-out at that concentration, not a potency): 11.7%
For compound 4 the middle estimate is 0.7 percentage points below the measured one; the range from low to high includes it.
By their numbers in this assay, from the lowest: compounds 3, 1, 4 and 2 (each within the scatter of the next).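

In this assay the exchange of pentyl for 4-(trifluoromethoxy)phenyl on this aromatic carbon gives a number 6.6 percentage points higher from compound 3 to compound 4 (within the scatter), so this third aryl group also leaves the series on the same flat level. Variation on the aryl ring itself is equally silent: trifluoromethoxy in place of bromo gives a number 1.3 percentage points higher from compound 1 to compound 4 (within the scatter) and 4-(trifluoromethoxy)phenyl in place of 2-fluorophenyl gives a number 3 percentage points lower from compound 2 to compound 4 (within the scatter), so no step at this position among these four compounds lies beyond the scatter. No measured evidence bears on this flat result.

Open, from the compounds shown here alone, is whether an amine or a carboxylic acid on this aromatic carbon would move the number beyond the scatter. Also open is whether any change elsewhere on the shared core would do so, and a single tested concentration gives no potency for any of these compounds.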